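Furan-2-yl for 2-chlorophenyl in a level series

A few compounds are considered here, and "the series" means these few. Any claim that something is new, unique, unknown or untested is made for them only; others in the source may bear on it.

In a functional assay on MCF7 cells (Homo sapiens) for cytotoxicity, read by MTT assay, with a stated time of 48 h (on this read-out higher numbers stand for weaker inhibition and lower numbers for stronger inhibition), compound 1 (`Cc1ncc([N+](=O)[O-])n1CCSc1nnc(-c2ccccc2)o1`) gives 20500 nM and compound 2 (`Cc1ccc(-c2nnc(SCCn3c([N+](=O)[O-])cnc3C)o2)cc1`) gives 15500 nM, while compound 3 (`Cc1ncc([N+](=O)[O-])n1CCSc1nnc(-c2ccccc2Cl)o1`) gives 22500 nM in the same range. All three lie within the scatter of one another, so compound 3 stands level with the other two. Compound 4 (`Cc1ncc([N+](=O)[O-])n1CCSc1nnc(-c2ccco2)o1`) has furan-2-yl in place of 2-chlorophenyl on an aromatic carbon of the five-membered aromatic ring with 2 nitrogen and 1 oxygen. Three measured steps at this place bear on the change: (a 1.3-fold lower number from compound 1 to compound 2 (0.12 log units; within the scatter)), (a 1.1-fold higher number from compound 1 to compound 3 (0.04 log units; within the scatter)) and (a 1.5-fold higher number from compound 2 to compound 3 (0.16 log units; within the scatter)), each within the scatter. Within the data shown here, all three compounds keep a six-membered aromatic ring of carbon only, so the data hold no direct precedent for furan-2-yl, and the range stays wide. No step beyond the scatter is expected in this assay for this change. The expected size is (a 1.1-fold lower number from compound 3 to compound 4 (0.05 log units; within the scatter)), with no firm direction. Compound 4 is estimated at 20000 nM (expected range 9500 nM to 42000 nM).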

Compound 4, half-maximal inhibitory concentration: 29500 nM
The estimate for compound 4 lay 1.5-fold (0.17 log units) below the measured number; low and high end bracket the measured number.
By their numbers in this assay, from the lowest: compounds 2, 1, 3 and 4 (each within the scatter of the next).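

Furan-2-yl is the first group at this place that is not a six-membered aromatic ring of carbon only, and in this assay the change from 2-chlorophenyl gives a 1.3-fold higher number from compound 3 to compound 4 (0.12 log units; within the scatter) on the shared core. The other two comparisons, a 1.4-fold higher number from compound 1 to compound 4 (0.16 log units; within the scatter) and a 1.9-fold higher number from compound 2 to compound 4 (0.28 log units; within the scatter), also stay within the scatter, so among these four compounds neither a five-membered aromatic ring with 1 hetero atom nor its hydrogen-bond acceptor separates compound 4 from the rest. No measurement shown here accounts for this level result.

Going by these compounds, all four groups at this place are aromatic rings, so it stays open whether an amine or a carboxylic acid there would give a step beyond the scatter. On these data alone, the effect of a longer chain in the linker of the shared core also stays open.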